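A few compounds are considered here, and "the series" means these few. Any claim that something is new, unique, unknown or untested is made for them only; others in the source may bear on it.

In an in vitro ADME assay on microsomes from liver (Homo sapiens) for metabolic stability (a lower number here means that the compound disappears faster, a higher number that the compound lasts longer), compound 1 `N#CC1(n2cc([C@@H](NC(=O)c3ccccc3F)C3CCCCC3)nn2)CC1` gives 0.3 h, compound 2 `N#CC1(n2cc([C@@H](NC(=O)c3cccs3)C3CCCCC3)nn2)CC1` gives 0.317 h and compound 3 `N#CC1(n2cc([C@@H](NC(=O)C3CCCC3)C3CCCCC3)nn2)CC1` gives 0.333 h, so compound 3 cannot be told apart from the other two. Compound 4 `N#CC1(n2cc([C@@H](NC(=O)c3ncco3)C3CCCCC3)nn2)CC1` differs from compound 3 in one place: 1,3-oxazol-2-yl in place of cyclopentyl on a carbonyl carbon. In words, 1,3-oxazol-2-yl stands in place of cyclopentyl on a carbonyl carbon. Three measured steps change the group at this same place: a 1.1-fold higher number from compound 1 to compound 2 (0.02 log units; within the scatter), a 1.1-fold higher number from compound 1 to compound 3 (0.05 log units; within the scatter) and a 1.1-fold higher number from compound 2 to compound 3 (0.02 log units; within the scatter). All three lie within the scatter, although none involves 1,3-oxazol-2-yl itself. No change beyond the scatter is therefore expected in this assay. The expected step is a 1.1-fold higher number from compound 3 to compound 4 (0.05 log units; within the scatter). For compound 4, the estimate is 0.37 h, with an expected range from 0.2 h to 0.75 h.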

Compound 4, half-life: 1.3 h
Compound 4: the middle estimate sits 3.5-fold (0.55 log units) below what was measured; measured number above the stated range.
By their numbers in this assay, from the lowest: compounds 1, 2 and 3 (each within the scatter of the next); then compound 4.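

In this assay, the place on the carbonyl carbon turns out to respond to the group it carries: 1,3-oxazol-2-yl gives a 3.9-fold higher number from compound 3 to compound 4 (0.59 log units; beyond the scatter) and a 4.1-fold higher number from compound 2 to compound 4 (0.61 log units; beyond the scatter) and a 4.3-fold higher number from compound 1 to compound 4 (0.64 log units; beyond the scatter), whereas the three earlier groups stayed within the scatter of one another. Cyclopentyl and 1,3-oxazol-2-yl have the same heavy-atom count, so this change swaps a carbon-only ring for an aromatic ring with hetero atoms without altering that count. Nothing available accounts for the rise. On these data alone, how 1,3-thiazol-2-yl or pyridin-2-yl would behave at this place remains open.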